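Swapping the charged ring at the end of a seven-carbon chain

The source may report more compounds than this note shows. Statements on the series, on what has been measured and on what is new or still open speak of the compounds shown alone.

Two compounds share one core and differ only in the charged ring carried at the end of the chain. Compound 1 `Cc1cc(OCCCCCCC[N+]2(C)CCCC2)cc(-n2cc(C(=O)Nc3cc(F)cc(F)c3)c(=O)c3ccc(N(C)C)nc32)c1` gives 4.32% in an assay on LX2 cells for inhibition of COL1A1 promoter (Homo sapiens), read by a luciferase reporter, with a stated time of 24 h, tested at 20 uM; on this read-out higher numbers stand for a stronger effect at the one concentration tested and lower numbers for a weaker effect. Compound 2 `Cc1cc(OCCCCCCC[n+]2ccccc2)cc(-n2cc(C(=O)Nc3cc(F)cc(F)c3)c(=O)c3ccc(N(C)C)nc32)c1` gives 7.7% in this assay, a number that stands alongside that of compound 1, since the step of a number 3.4 percentage points higher from compound 1 to compound 2 (within the scatter) is within the scatter; both compounds show only a weak effect at the single concentration tested. Compound 3 `Cc1cc(OCCCCCCC[N+]2(C)CCN(C)CC2)cc(-n2cc(C(=O)Nc3cc(F)cc(F)c3)c(=O)c3ccc(N(C)C)nc32)c1` has not yet been measured. It differs from compound 2 in this way: a group of 8 heavy atoms (6 carbon, 2 nitrogen; one six-membered non-aromatic ring with 2 hetero atoms) in place of a group of 6 heavy atoms (5 carbon, 1 nitrogen; one six-membered aromatic ring with 1 hetero atom), on a saturated chain carbon, seven bonds along the chain from an oxygen on an aromatic ring. Among the compounds with values here, the only measured step that bears on this change is a number 3.4 percentage points higher from compound 1 to compound 2 (within the scatter), which exchanged one charged ring for another at the same place and moved the number by no more than the scatter. On that basis compound 3 is expected to show a step of a number 1.7 percentage points lower from compound 2 to compound 3 (within the scatter) in this assay, none beyond the scatter. Compound 3 is therefore estimated at 6%, with a range from -6% to 18%.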

Compound 3, a percentage reported as inhibition, at one concentration (the size of the read-out at that concentration, not a potency): 2.8%
Beside the measured number, compound 3's estimate is 3.2 percentage points above it, within the range that was stated.
By their numbers in this assay, from the lowest: compounds 3, 1 and 2 (each within the scatter of the next).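

Compound 3 brings a third kind of ring to this place, a six-membered non-aromatic ring with 2 hetero atoms and 1 hydrogen-bond acceptor, and in this assay the outcome is a number 4.9 percentage points lower from compound 2 to compound 3 (within the scatter) and a number 1.5 percentage points lower from compound 1 to compound 3 (within the scatter). The three rings therefore stand alongside one another, so neither the aromatic ring, the five-membered ring nor the entering group, with its larger heavy-atom count, sets any compound apart at this place. Nothing on hand offers an explanation for this result.

From the compounds shown here alone, all three groups carry a net charge of +1, so it remains open how a primary amine or a carboxylic acid at the end of the chain would read. Also open, going by these compounds, is whether a longer chain would move the number beyond the scatter.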